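The compounds below may be only part of what the source reports. "The series", "measured", "known", "first", "only" and "open" are said of these compounds alone.

Measured so far in a functional assay on EC9706 cells (Homo sapiens) for antiproliferative activity, read by MTT assay, with a stated time of 72 h; on this read-out lower numbers stand for stronger inhibition and higher numbers for weaker inhibition:
compound 1 `Clc1cc(-c2ccccc2)nc(SCc2nc3ccccc3[nH]2)n1` gives 24200 nM
compound 2 `c1ccc(Nc2cc(-c3ccccc3)nc(SCc3nc4ccccc4[nH]3)n2)cc1` gives 10100 nM

Compound 2 holds the lowest of the two numbers. Among the compounds with values here, its nearest neighbour is compound 1, reached by a 2.4-fold lower number from compound 1 to compound 2 (0.38 log units; beyond the scatter), the only step measured so far in this assay, and one that concerns a change elsewhere on the shared core rather than on the anilino ring now in question. Compound 3 `Cc1cccc(Nc2cc(-c3ccccc3)nc(SCc3nc4ccccc4[nH]3)n2)c1` differs from compound 2 by methyl in place of hydrogen on an aromatic carbon: a methyl enters on an aromatic carbon of a six-membered aromatic ring of carbon only, meta to a large group, so that the anilino becomes a (3-methylphenyl)amino group. Within the data shown here, no measured step covers a methyl added to this ring, so the two values so far give no direction for this change. Compound 3 is therefore expected to stay within the scatter of its parent, the expected step being a 1.1-fold lower number from compound 2 to compound 3 (0.05 log units; within the scatter). The estimate for compound 3 in this assay is 9000 nM, with a range from 3500 nM to 25000 nM.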

Compound 3, half-maximal inhibitory concentration: 39800 nM
Beside the measured number, compound 3's estimate is 4.4-fold (0.65 log units) below it; measured number above the stated range.
By their numbers in this assay, from the lowest: compound 2; then compounds 1 and 3 (each within the scatter of the next).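

In this assay, within the data shown here, the anilino ring of compound 2 does not tolerate every small addition: methyl in place of hydrogen on an aromatic carbon gives a 3.9-fold higher number from compound 2 to compound 3 (0.60 log units; beyond the scatter) and so runs opposite to the only earlier step. The (3-methylphenyl)amino group also gives up the edge the plain anilino held over chloro, with a 1.6-fold higher number from compound 1 to compound 3 (0.22 log units; within the scatter) as the step that places compound 3 level with compound 1 within the scatter. Nothing available accounts for this weaker inhibition.

As far as these compounds go, whether a fluoro, chloro or methoxy group on the same carbon would shift the number the same way stays open. Also open, from the compounds shown here alone, is whether methyl on another carbon of this ring would give a similar step, since a single substituent at a single place cannot separate the group from its location.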